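Replacing butoxy with anilino: working notes on compound 4

The source may report more compounds than this note shows. Statements on the series, on what has been measured and on what is new or still open speak of the compounds shown alone.

In a functional assay on HeLa cells (Homo sapiens) for inhibition, read by sulforhodamine B assay, with a stated time of 48 h (a higher number here means a weaker inhibitor of growth, a lower number a stronger inhibitor of growth), compound 1 (`Cc1cc(=O)oc2cc(N=C=[Se])ccc12`) gives 12000 nM. Compound 2 (`CCOC(=[Se])Nc1ccc2c(C)cc(=O)oc2c1`) gives > 100000 nM, and this value is a limit, not a number. For compound 3 (`CCCCOC(=[Se])Nc1ccc2c(C)cc(=O)oc2c1`) no number exists: its entry reads "nd(insoluble)" (no result reported). The nearest reference for compound 3 is therefore the value of compound 2, (the limit of > 100000 nM in this assay, at which 1 of the 3 values shown sits).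

Compound 4 (`Cc1cc(=O)oc2cc(NC(=[Se])Nc3ccccc3)ccc12`) follows from compound 3 by anilino in place of butoxy on a saturated chain carbon bound to a nitrogen on an aromatic ring. Among the compounds with values here, no measured step covers this exchange, and with no number for compound 3 its size cannot be anchored there. Within the data shown here, the one measured step bears only indirectly: an at least 8.3-fold higher number from compound 1 to compound 2 (0.92 log units; beyond the scatter). Enlarging the group on the aromatic carbon thus gave a higher number, so a value higher than that of compound 1 is expected in this assay, perhaps reaching the limit. For compound 4 the estimated value is 35000 nM, with an expected range of 8000 nM to 100000 nM.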

Compound 4, concentration for 50% growth inhibition: 24000 nM
The estimate for compound 4 lay 1.5-fold (0.16 log units) above the measured number, within the range that was stated.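

In this assay, replacing ethoxy with anilino gives an at least 4.1-fold lower number from compound 2 to compound 4 (0.61 log units; beyond the scatter). From the compounds shown here alone, compound 2 holds a limit and not a number, so the full size of this step stays unknown: the limit of > 100000 nM in this assay, at which 1 of the 4 values shown sits. Among compound 2, compound 3 and compound 4, which differ only at this place, compound 4 alone has a number, and the change shows that this place can take a group that lowers the value, which the earlier step did not show.

The exchange of butoxy for anilino cannot be read, as compound 3 has no number. Also open, going by these compounds, is whether the ring or the nitrogen carrying it accounts for the step: phenoxy or a butylamino group at this place would separate the two.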